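This account rests on a few compounds, and the source may have more. Where it says the series, first, only, none or still open, it means among the compounds named here.

Compound 1 `N#Cc1ccc(NC(=O)c2cc(Cl)ccc2O)c(Cl)c1` and compound 2 `N#Cc1ccc(NC(=O)c2cc(F)ccc2O)cc1` have cores that are not the same, and the difference between the two cores is not broken down here. In a functional assay on KG-1 cells (Homo sapiens) for cytotoxicity, read by luminescence and CellTiter-Glo, with a stated time of 3 days (a higher number here means a weaker inhibitor, a lower number a stronger inhibitor), compound 1 gives 860 nM, and compound 2 gives 2670 nM. Compound 3 `O=C(Nc1ccc(OC(F)(F)F)cc1)c1cc(F)ccc1O` differs from compound 2 by trifluoromethoxy in place of cyano on an aromatic carbon; in this assay compound 3 gives 780 nM, a step of a 3.4-fold lower number from compound 2 to compound 3 (0.53 log units; beyond the scatter). Compound 4 `O=C(Nc1ccc(OC(F)(F)F)cc1Cl)c1cc(Cl)ccc1O` differs from compound 1 by the same kind of change, (trifluoromethoxy in place of cyano on an aromatic carbon); in compound 1 the place is also meta to a chloro group (1 heavy atom), so the two changes are not the same. Compound 1 and compound 3 lie within the scatter of each other. For compound 4 a step of a 2.3-fold lower number from compound 1 to compound 4 (0.35 log units; beyond the scatter) is expected, kept smaller than the earlier one because a 3.4-fold lower number from compound 2 to compound 3 (0.53 log units; beyond the scatter) was measured on a different core. The estimate for compound 4 is 380 nM, with a range from 150 nM to 950 nM.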

Compound 4, half-maximal inhibitory concentration: 620 nM
Compound 4: middle estimate off by 1.6-fold (0.21 log units), on the low side; measured number inside the range.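

In this assay, trifluoromethoxy in place of cyano on an aromatic carbon gives a 1.4-fold lower number from compound 1 to compound 4 (0.14 log units; within the scatter), and this new step can be set beside the earlier one: the same change on two cores in this assay, a 3.4-fold lower number (0.53 log units; beyond the scatter) from compound 2 to compound 3 and a 1.4-fold lower number (0.14 log units; within the scatter) from compound 1 to compound 4, 2.5-fold (0.39 log units) apart, within the scatter of two such steps. The two steps therefore give no sign that the change behaves differently on the two cores, although only the earlier step lies beyond the scatter. Resting on just two pairs, this does not show that the step has one fixed size or that it would carry to any further core.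

The compounds shown leave open how an amine or a carboxylic acid would compare at this place on either core. They also leave open whether the same step would hold on a core carrying neither chloro nor fluoro.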